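Changing the aryl group on the hydrazone of compound 3

A few compounds are considered here, and "the series" means these few. Any claim that something is new, unique, unknown or untested is made for them only; others in the source may bear on it.

Compound 1 `CN(C)CCn1cnnc1-c1cc(Oc2ccc(NC(=O)N/N=C/c3cc(C(C)(C)C)cc(C(C)(C)C)c3O)cc2F)ccn1`: in a functional assay on A549 cells (Homo sapiens) for cytotoxicity, read by MTT assay, with a stated time of 72 h (on this read-out lower numbers stand for stronger inhibition and higher numbers for weaker inhibition), compound 1 gives 980 nM.
Compound 2 `Cn1ncnc1-c1cc(Oc2ccc(NC(=O)N/N=C/c3ccccc3)cc2F)ccn1`: in this assay compound 2 gives only a limit, > 100000 nM.
Compound 3 `COc1cc(/C=N/NC(=O)Nc2ccc(Oc3ccnc(-c4nncn4CCN(C)C)c3)c(F)c2)cc(OC)c1OC`: in this assay compound 3 gives only a limit, > 100000 nM.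

Compound 3 therefore stands at the weak end of what is shown, sharing the limit of > 100000 nM in this assay, at which 2 of the 3 values shown sit, with compound 2, while only compound 1 yields a number. Among the measured compounds shown here, no step between two measured compounds is available to size a change here. Compound 4 `CN(C)CCn1cnnc1-c1cc(Oc2ccc(NC(=O)N/N=C/c3ccc(O)c(F)c3)cc2F)ccn1` differs from compound 3 by 3-fluoro-4-hydroxyphenyl in place of 3,4,5-trimethoxyphenyl on a carbon with a double bond to nitrogen. The new group carries a hydroxyl, as compound 1 does, though compound 1 also bears two tert-butyl groups. A step toward stronger inhibition is expected, an at least 2.5-fold lower number from compound 3 to compound 4 (0.39 log units; beyond the scatter), but it cannot be measured against a limit. Compound 4 is expected near 40000 nM, between 4000 nM and 200000 nM.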

Compound 4, half-maximal inhibitory concentration: 13400 nM
Compound 4: the middle estimate sits 3.0-fold (0.47 log units) above what was measured, within the range that was stated.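

In this assay, putting 3-fluoro-4-hydroxyphenyl in place of 3,4,5-trimethoxyphenyl on the carbon with a double bond to nitrogen gives an at least 7.4-fold lower number from compound 3 to compound 4 (0.87 log units; beyond the scatter). Among the compounds shown here, this is the first sized step here, and it shows that this aryl group alone can shift the read-out beyond the usual scatter. Compound 3 holds only a limit of the assay, so the full size of the step stays unknown: the limit of > 100000 nM in this assay, at which 2 of the 4 values shown sit.

Still open, from the compounds shown here alone, is whether the hydroxyl or the fluorine accounts for the change. Going by these compounds, how a plain 4-hydroxyphenyl or a 4-aminophenyl would read at this place also remains unknown.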